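The source may report more compounds than this note shows. Statements on the series, on what has been measured and on what is new or still open speak of the compounds shown alone.

Measured in an ADME assay on MRC5 cells (Homo sapiens) for cytotoxicity, read by MTT assay, with a stated time of 72 h; a lower number here means a stronger inhibitor, a higher number a weaker inhibitor:
Compound 1 `CC(C)(C)C1=CC(=O)C=C(NCCC(=O)O)C1=O`: > 200000 nM, a limit.
Compound 2 `CC1=CCC[C@H]2[C@](C)(CC3=CC(=O)C(N4CCC[C@H]4C(=O)O)=CC3=O)[C@@H](C)CC[C@]12C`: 96000 nM.
Compound 3 `CC1=CCC[C@H]2[C@](C)(CC3=CC(=O)C=C(NCCC(=O)O)C3=O)[C@@H](C)CC[C@]12C`: 80800 nM.

Compound 1 stands at the limit of > 200000 nM in this assay, at which 1 of the 3 values shown sits. It therefore has no number of its own in this assay. Compound 2 gives 96000 nM and compound 3 gives 80800 nM, and these two values lie within the usual scatter of each other.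

The next compound to be tested is compound 4 `C[C@H](NC1=CC(=O)C=C(C(C)(C)C)C1=O)C(=O)O`. It has the same atoms as compound 1, joined differently, with 1-carboxyethyl in place of 2-carboxyethyl on an amine nitrogen. The rest of the core of compound 1 stays as it is.

Within the data shown here, no measured pair of compounds differs in one place, so the data do not gauge this change directly. No step beyond the scatter is expected in this assay. This expectation rests on compound 1, whose reading of > 200000 nM is a limit. The estimated change, a number no higher from compound 1 to compound 4 (the limit leaves the size open), is expected to be small, and the result may again be only a limit. For compound 4 the expected value is 200000 nM, with an estimated range from 100000 nM to 400000 nM.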

Compound 4, half-maximal inhibitory concentration: > 200000 nM
Compound 4: no number, only a limit (the forecaster's own chance of this, stated with the estimate: 70%); the middle value lies on the limit itself.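

In this assay compound 4 gives > 200000 nM, which is a limit. Compound 1 and compound 4 therefore both lack a number of their own, so no step can be read between them: the limit of > 200000 nM in this assay, at which 2 of the 4 values shown sit.

The compounds shown leave open whether 1-carboxyethyl in place of 2-carboxyethyl on an amine nitrogen changes the reading at all.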